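A Longer Side Chain on a Low-Cytotoxicity Compound

A few compounds are considered here, and "the series" means these few. Any claim that something is new, unique, unknown or untested is made for them only; others in the source may bear on it.

Values so far in an ADME assay on BJ cells (Homo sapiens) for cytotoxicity, with a stated time of 72 h; a lower number here means that less compound is needed, a higher number that more compound is needed for the effect 
- Compound 1 `COc1cc2ncnc(-n3nc(-c4ccccn4)nc3N)c2cc1[N+](=O)[O-]` gives > 13000 nM as a limit
- Compound 2 `COc1cc2ncnc(-n3nc(-c4ccccn4)nc3N)c2cc1OCCCN(C)C` gives > 25000 nM as a limit

Compound 2 stands at > 25000 nM and this is a limit, not a number. Compound 3 (`COc1cc2ncnc(-n3nc(-c4ccccn4)nc3N)c2cc1OCCCNC(=O)CN1C[C@@H](C)O[C@@H](C)C1`) shares its core and differs on the side chain: (((2,6-dimethylmorpholin-4-yl)methyl)carbonyl)amino in place of dimethylamino on a saturated chain carbon, three bonds along the chain from an oxygen on an aromatic ring Here (((2,6-dimethylmorpholin-4-yl)methyl)carbonyl)amino takes the place of dimethylamino on a saturated chain carbon, three bonds along the chain from an oxygen on an aromatic ring.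

Among the measured compounds shown here, only one measured step bears on this change. It is a step that the two limits leave unreadable from compound 1 to compound 2 and it puts 3-(dimethylamino)propoxy in place of nitro on an aromatic carbon. That step has no readable size to carry over, and it does not involve the new group. No step beyond the usual scatter is therefore expected in this assay and another limit is the likeliest report. The expected size is a number no higher from compound 2 to compound 3 (the limit leaves the size open) as an estimate. The estimate for compound 3 is 25000 nM with an expected range from 8000 nM to 60000 nM in this read-out.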

Compound 3, half-maximal effective concentration: > 25000 nM
Compound 3 gave a limit, no number (the forecaster's own chance of this, stated with the estimate: 65%); the middle value sits exactly at the limit.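

No step can be read between compound 2 and compound 3, because both report a limit of the assay and not a number: the limit of > 25000 nM in this assay, at which 2 of the 3 values shown sit.

The compounds shown leave open what concentration of compound 2 or compound 3 would actually reach the half-maximal effect in this assay, and so whether replacing dimethylamino with the longer (((2,6-dimethylmorpholin-4-yl)methyl)carbonyl)amino group changes that concentration at all.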